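From methyl ester to primary amide on the side chain

The compounds below may be only part of what the source reports. "The series", "measured", "known", "first", "only" and "open" are said of these compounds alone.

In a functional assay on SK-BR-3 cells (Homo sapiens) for antiproliferative activity (a higher number here means a weaker inhibitor, a lower number a stronger inhibitor), compound 1 `CC(C)=CCc1cc(C(=O)Nc2cc3ccc(OCCCN4CCCCC4)c(C)c3oc2=O)ccc1O` reports only a limit, > 50000 nM. Compound 2 `CC(C)=CCc1cc(C(=O)Nc2cc3ccc(OCCCNC(C)(C)C)c(C)c3oc2=O)ccc1O` gives 660 nM. Compound 3 `COC(=O)CNCCCOc1ccc2cc(NC(=O)c3ccc(O)c(CC=C(C)C)c3)c(=O)oc2c1C` gives 1060 nM, which puts it level with compound 2. Both sit far from compound 1, with an at least 75-fold lower number from compound 1 to compound 2 (1.87 log units; beyond the scatter) and an at least 47-fold lower number from compound 1 to compound 3 (1.67 log units; beyond the scatter), each a large step that removes the piperidin-1-yl group.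

Compound 4 `CC(C)=CCc1cc(C(=O)Nc2cc3ccc(OCCCNCC(N)=O)c(C)c3oc2=O)ccc1O` differs from compound 3 in one place: amino in place of methoxy on a carbonyl carbon. This is amino in place of methoxy on a carbonyl carbon, so (methoxycarbonyl)methyl becomes carbamoylmethyl. Compound 4 has no piperidin-1-yl group, so the two large steps offer little guidance here. The closest evidence is the change on the amine nitrogen, a 1.6-fold higher number from compound 2 to compound 3 (0.21 log units; within the scatter), which stays within the scatter. A change further out on that same substituent is therefore expected to produce no step beyond the scatter in this assay. The expected step is a 1.1-fold higher number from compound 3 to compound 4 (0.05 log units; within the scatter). For compound 4 the estimated value is 1200 nM, with an expected range from 450 nM to 3500 nM.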

Compound 4, half-maximal inhibitory concentration: 2290 nM
For compound 4 the middle estimate is 1.9-fold (0.28 log units) below the measured one; measured number inside the range.
By their numbers in this assay, from the lowest: compounds 2 and 3 (each within the scatter of the next); then compound 4. At a limit, above all of these: compound 1.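

In this assay, the amino-for-methoxy change on the carbonyl carbon gives a 2.2-fold higher number from compound 3 to compound 4 (0.33 log units; beyond the scatter), showing that an edit further out on this side chain can move the number beyond the scatter. The earlier swap on the amine nitrogen had stayed within it, whereas carbamoylmethyl in place of tert-butyl gives a 3.5-fold higher number from compound 2 to compound 4 (0.54 log units; beyond the scatter), so these two amine substituents are not interchangeable in this assay, although the step is only modest. Compound 4 nevertheless stays well apart from the piperidin-1-yl compound, with an at least 21-fold lower number from compound 1 to compound 4 (1.33 log units; beyond the scatter), a figure that is only a bound because compound 1 stands at a limit: the limit of > 50000 nM in this assay, at which 1 of the 4 values shown sits.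

The compounds shown leave open whether a carboxylic acid on this carbonyl carbon would read closer to compound 3 or to compound 4. They also leave open whether a longer chain between the amine nitrogen and the carbonyl would change the size of this step.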